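The source may hold more compounds than are shown below. What is called first, only, known or untested is meant among the compounds shown, and "the series" means these compounds.

Compound 1 `CNc1ncccc1C(=O)N/N=C/c1ccccc1` gives 22.7% in a functional assay on the whole organism (strain Wistar) for inhibition, with Rattus norvegicus as the target, read by paw edema, with a stated time of 3 h, at a dose of 10 mg/kg by the intraperitoneal route (a lower number here means less inhibition, a higher number more inhibition at the dose given (going by the name of the read-out)), and stands lowest of the three measured compounds. Compound 2 `CNc1ncccc1C(=O)N/N=C/c1cccc(Cl)c1` gives 39.6%, and compound 3 `CNc1ncccc1C(=O)N/N=C/c1cccc(OC)c1` gives 49.5%. The two measured steps from compound 1 both come from a group entering the phenyl ring: a number 16.9 percentage points higher from compound 1 to compound 2 (beyond the scatter) and a number 26.8 percentage points higher from compound 1 to compound 3 (beyond the scatter). Compound 4 `CNc1ncccc1C(=O)N/N=C/c1ccncc1` differs from compound 1 in another way: pyridin-4-yl in place of phenyl on a carbon with a double bond to nitrogen. Among the measured compounds shown here, no measured step replaces the ring itself, so the two steps bear on compound 4 only loosely; a change to the ring in compound 1 twice raised inhibition in this assay, which gives a weak lean upward. Compound 4 is therefore expected to show a number 7.3 percentage points higher from compound 1 to compound 4 (within the scatter), a step not surely beyond the scatter. The estimate for compound 4 is 30%, ranging from 12% to 50%.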

Compound 4, a percentage reported as inhibition, in the whole organism at one dose (the size of the read-out at that dose, not a potency): 55%
Beside the measured number, compound 4's estimate is 25 percentage points below it; the measured number lies above the stated range.
By their numbers in this assay, from the lowest: compound 1; then compounds 2, 3 and 4 (each within the scatter of the next, the first and the last beyond it).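

Replacing the whole ring on the carbon with a double bond to nitrogen, rather than adding a group to the phenyl ring, also changes the read-out: in this assay the pyridin-4-yl change gives a number 32.3 percentage points higher from compound 1 to compound 4 (beyond the scatter). A ring nitrogen alone, with no added heavy atoms and one hydrogen-bond acceptor gained, is therefore enough for a large step at this place. Nothing measured here explains the step.

On these data alone, whether pyridin-2-yl or pyridin-3-yl would behave like pyridin-4-yl remains open. So does whether a methoxy or chloro group on the pyridin-4-yl ring would raise the number further.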